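Swapping the Amine on the Acrylamide Side Chain

The source may hold more compounds than are shown below. What is called first, only, known or untested is meant among the compounds shown, and "the series" means these compounds.

Compound 1, `COc1cc2ncnc(N3CCCc4ccccc43)c2cc1NC(=O)/C=C/C(C)C`, gives 4290 nM in a functional assay on MCF7 cells (Homo sapiens) for antiproliferative activity, read by MTT assay, with a stated time of 72 h; on this read-out higher numbers stand for weaker inhibition and lower numbers for stronger inhibition.
Compound 2, `CCC/C=C/C(=O)Nc1cc2c(N3CCCc4ccccc43)ncnc2cc1OC`, gives 1210 nM in this assay.
Compound 3, `COc1cc2ncnc(N3CCCc4ccccc43)c2cc1NC(=O)/C=C/CN1CCCC1`, gives 3190 nM in this assay.

Among these three, compound 3 stands second highest in this assay. Its nearest neighbour is compound 1, since a 1.3-fold lower number from compound 1 to compound 3 (0.13 log units; within the scatter). Its furthest is compound 2, because a 2.6-fold higher number from compound 2 to compound 3 (0.42 log units; beyond the scatter).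

Compound 4, `COc1cc2ncnc(N3CCCc4ccccc43)c2cc1NC(=O)/C=C/CN1CCN(C)CC1`, is not yet measured. It differs from compound 3 in one place: 4-methylpiperazin-1-yl in place of pyrrolidin-1-yl on a saturated chain carbon bound to a double-bonded chain carbon.

Going by the values given here, no measured step exchanges one amine ring for another on this chain. Among the compounds with values here, the one step that touches the amine, from an ethyl to a pyrrolidin-1-yl, was modest: a 2.6-fold higher number from compound 2 to compound 3 (0.42 log units; beyond the scatter). The other step into compound 3 stayed small: a 1.3-fold lower number from compound 1 to compound 3 (0.13 log units; within the scatter). Both shifts were modest, and the present change keeps an amine ring in the same place, so for compound 4 the expected step is a 1.1-fold higher number from compound 3 to compound 4 (0.04 log units; within the scatter), with no change beyond the scatter. Compound 4 is therefore estimated at 3500 nM, within 1500 nM to 8000 nM.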

Compound 4, half-maximal inhibitory concentration: 8560 nM
For compound 4 the middle estimate is 2.4-fold (0.39 log units) below the measured one, outside the stated range (above it).
By their numbers in this assay, from the lowest: compound 2; then compounds 3, 1 and 4 (each within the scatter of the next, the first and the last beyond it).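

Exchanging one amine ring for another at this saturated chain carbon does shift the result in this assay (a 2.7-fold higher number from compound 3 to compound 4 (0.43 log units; beyond the scatter)), so 4-methylpiperazin-1-yl and pyrrolidin-1-yl cannot be treated as interchangeable here. Compared with the ethyl group of compound 2, 4-methylpiperazin-1-yl gives a larger step (a 7.1-fold higher number from compound 2 to compound 4 (0.85 log units; beyond the scatter)), whereas the comparison with the isopropyl-bearing compound 1 stays within the scatter (a 2.0-fold higher number from compound 1 to compound 4 (0.30 log units; within the scatter)). Nothing shown here explains the difference between the two rings.

These compounds do not separate the effect of ring size from that of the second ring nitrogen and its methyl group. Piperidin-1-yl, morpholin-4-yl or unsubstituted piperazin-1-yl at this carbon could help pull those apart, while a dimethylamino group would ask whether a ring is needed at all.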